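This account rests on a few compounds, and the source may have more. Where it says the series, first, only, none or still open, it means among the compounds named here.

Measured so far:
compound 1 `CN1CCN(CCCOc2cccc3nc(Nc4ccc(F)c(F)c4)ccc23)CC1`: 5660 nM
compound 2 `CN1CCN(CCCOc2cccc3nc(Nc4cc(Cl)cc(Cl)c4)ccc23)CC1`: 1780 nM

In a functional assay on A498 cells (Homo sapiens) for inhibition, read by sulforhodamine B assay, with a stated time of 48 h (a higher number here means a weaker inhibitor of growth, a lower number a stronger inhibitor of growth), compound 2 gives 1780 nM, the lowest of the two numbers, with compound 1 the only other point: a 3.2-fold lower number from compound 1 to compound 2 (0.50 log units; beyond the scatter). Compound 3 `CN1CCN(CCCOc2cccc3nc(Nc4ccc(Cl)c(F)c4)ccc23)CC1` is the next compound; (4-chloro-3-fluorophenyl in place of 3,5-dichlorophenyl on a nitrogen on an aromatic ring). For the measured compounds named here, the one step that bears on this is the same swap of halogens on this phenyl ring, and it was modest. Compound 3 carries a fluorine like compound 1 and a chlorine like compound 2, so a mild move back toward compound 1 seems likely. The expected step is thus a 1.8-fold higher number from compound 2 to compound 3 (0.25 log units; within the scatter). Compound 3 is expected to give about 3200 nM, between 1400 nM and 7500 nM.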

Compound 3, concentration for 50% growth inhibition: 2390 nM
Compound 3: middle estimate off by 1.3-fold (0.13 log units), on the high side, within the range that was stated.
By their numbers in this assay, from the lowest: compounds 2 and 3 (each within the scatter of the next); then compound 1.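

In this assay the step of a 1.3-fold higher number from compound 2 to compound 3 (0.13 log units; within the scatter) shows that 4-chloro-3-fluorophenyl and 3,5-dichlorophenyl on this nitrogen cannot be told apart. The step of a 2.4-fold lower number from compound 1 to compound 3 (0.37 log units; beyond the scatter) shows that chloro in place of fluoro on a single aromatic carbon is enough on its own to move the number beyond the scatter. Nothing measured here offers an explanation for either step.

On these data alone, all three rings carry only fluoro and chloro, so it stays open how a ring bearing bromo, methoxy or trifluoromethyl, or an unsubstituted phenyl, would compare.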